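A few compounds are considered here, and "the series" means these few. Any claim that something is new, unique, unknown or untested is made for them only; others in the source may bear on it.

Measured compounds:
Compound 1, `CNCc1cc(-c2cccnc2F)n(S(=O)(=O)c2cccnc2)c1`, in a functional assay on the whole organism (strain Jcl:Sprague-Dawley) for inhibition, with Rattus norvegicus as the target, with stated times of 3 min and 3 h, at a dose of 1 mg/kg by the intravenous route (a higher number here means more inhibition at the dose given (going by the name of the read-out), a lower number less inhibition), gives 96%.
Compound 2, `CNCc1cc(-c2cccnc2F)n(S(=O)(=O)c2cccs2)c1`, gives 96%.
Compound 3, `CNCc1cn(S(=O)(=O)c2ccoc2)c(-c2cccnc2F)c1F`, gives 95%.

Compound 3 has the lowest of the three numbers, but its nearest neighbour is compound 1 and its furthest is compound 2, and both lie within the scatter of it, so the three measured values read as one level rather than an order.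

Compound 4, `CNCc1cn(S(=O)(=O)c2ncccc2C)c(-c2cccnc2F)c1F`, has not yet been measured. It differs from compound 3 in one place:

3-methylpyridin-2-yl in place of furan-3-yl on a sulfonyl sulfur

The group on the sulfonyl sulfur changes from a five-membered aromatic ring to a six-membered one, while the rest of the shared core is kept.

Within the data shown here, one measured step bears on a change of this kind: no change at the digits printed from compound 1 to compound 2 (within the scatter). There an exchange of one aromatic ring for another on the same sulfonyl sulfur left the read-out where it was. Among the measured compounds shown here, with only that step to go on, the expectation for the step from compound 3 to compound 4 in this assay is a number 1 percentage points lower from compound 3 to compound 4 (within the scatter), that is, no change beyond the scatter.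

Compound 4 is therefore estimated at 94%, with a range from 82% to 99%.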

Compound 4, a percentage reported as inhibition, in the whole organism at one dose (the size of the read-out at that dose, not a potency): 54%
Compound 4: middle estimate off by 40 percentage points, on the high side; the measured number lies below the stated range.
By their numbers in this assay, from the lowest: compound 4; then compounds 3, 1 and 2 (each within the scatter of the next).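

In this assay, the group on the sulfonyl sulfur turns out to matter a great deal: putting 3-methylpyridin-2-yl in place of furan-3-yl gives a number 41 percentage points lower from compound 3 to compound 4 (beyond the scatter). Among these compounds, the only earlier step at this place, no change at the digits printed from compound 1 to compound 2 (within the scatter), made the read-out look indifferent to which aromatic ring sits there, but the new step shows that this indifference does not extend to every ring. The entering group differs from the leaving one both in having a six-membered rather than a five-membered ring and in carrying a methyl, and nothing available here explains why the read-out falls.

As far as these compounds go, a single step cannot separate these differences, so it remains open whether the drop follows the six-membered ring, the methyl or the place of the ring nitrogen. A plain pyridin-2-yl ring without the methyl, or a phenyl ring on the same sulfonyl sulfur of the core of compound 3, would help to pull these apart, and how either would read out cannot be told from the compounds shown.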